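From ethynyl to azidomethyl on the carbonyl carbon

The source may hold more compounds than are shown below. What is called first, only, known or untested is meant among the compounds shown, and "the series" means these compounds.

Working notes on the series in a functional assay on KYSE-450 cells (Homo sapiens) for inhibition, read by MTT assay, with a stated time of 48 h; a lower number here means a stronger inhibitor, a higher number a weaker inhibitor. Compound 1 (`C/C=C/C(=O)N(Cc1ccc(OC)c(OC)c1)c1cc(OC)c(OC)c(OC)c1`) gives 39100 nM, and compound 3 (`COc1ccc(CNc2cc(OC)c(OC)c(OC)c2)cc1F`) gives 46200 nM. Compound 2 (`C#CC(=O)N(Cc1ccc(OC)c(O)c1)c1cc(OC)c(OC)c(OC)c1`) gives 570 nM, the lowest of the three numbers, and the other two lie above it beyond the scatter.

Next in line is compound 4 (`COc1ccc(CN(C(=O)CN=[N+]=[N-])c2cc(OC)c(OC)c(OC)c2)cc1O`), which carries azidomethyl in place of ethynyl on a carbonyl carbon. Among the compounds with values here, no measured pair isolates this change, so the expectation rests on thin evidence. Among the measured compounds, only compound 2 carries ethynyl on a carbonyl carbon, at 570 nM. Compound 1 has a different group there and also differs elsewhere, and it stands at 39100 nM. A rise in this assay beyond the scatter is therefore expected, stopping short of the number of compound 1. The estimated step is a 14-fold higher number from compound 2 to compound 4 (1.15 log units; beyond the scatter). For compound 4 the expected value is 8000 nM, with an estimated range of 1500 nM to 35000 nM.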

Compound 4, half-maximal inhibitory concentration: 160 nM
The estimate for compound 4 lay 50-fold (1.70 log units) above the measured number; measured number outside the range, below it.
By their numbers in this assay, from the lowest: compound 4; then compound 2; then compounds 1 and 3 (each within the scatter of the next).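

Within this assay azidomethyl in place of ethynyl on a carbonyl carbon brings a 3.6-fold lower number from compound 2 to compound 4 (0.55 log units; beyond the scatter) and so shows that ethynyl is not required at this position for the lower numbers of the series. The position accepts azidomethyl, with 4 heavy atoms against 2 for ethynyl, and no triple bond remains outside the aromatic rings, yet the number still falls, though the step is modest. Nothing at hand gives a reason for this step.

On these data alone, it remains open whether the fall belongs to the azide itself or to the longer chain on the carbonyl carbon, a question that chloromethyl, aminomethyl or a plain ethyl group at this position could help to settle. As far as these compounds go, it also remains open whether the same change gives a step of similar size with a methoxy group in place of the hydroxyl on the benzyl ring.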